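The compounds below may be only part of what the source reports. "The series", "measured", "known", "first", "only" and "open" are said of these compounds alone.

Two compounds of the series have numbers in an assay on membranes from brain for binding affinity to adenosine receptor A1 (Rattus norvegicus); a lower number here means a stronger inhibitor, a higher number a weaker inhibitor. Compound 1 `COc1ccc(-c2oc3cc(OC)cc(OC)c3c(=O)c2OC)c(OC)c1` gives 27600 nM. Compound 2 `O=C1CC(c2ccccc2O)Oc2ccccc21` gives 2640 nM, the lower of the two numbers, and its gap to compound 1 lies beyond the scatter. Within the data shown here, no two measured compounds differ in one place only, so no single structural step has been measured yet, and the gap between compound 1 and compound 2 covers several changes at once.

Compound 3 `O=C1c2ccccc2OC(c2ccccc2O)C1O` is not yet measured. It differs from compound 2 by hydroxy in place of hydrogen on a saturated ring carbon. Among the measured compounds shown here, no measured pair shows the effect of such a change in this assay. The expected step is a 1.3-fold higher number from compound 2 to compound 3 (0.12 log units; within the scatter), close to the scatter, leaning if anything toward a weaker inhibitor. For compound 3 the estimated value is 3500 nM, with a range from 1200 nM to 10000 nM.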

Compound 3, inhibition constant: 91900 nM
Compound 3: middle estimate off by 26-fold (1.42 log units), on the low side, outside the stated range (above it).
By their numbers in this assay, from the lowest: compound 2; then compound 1; then compound 3.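

Among these compounds, at the saturated ring carbon two ring bonds from the ring oxygen, hydroxy in place of hydrogen is far from a neutral change in this assay: it gives a 35-fold higher number from compound 2 to compound 3 (1.54 log units; beyond the scatter), and this is the first single-place step. Compound 3 is thus a much weaker inhibitor than compound 2, which shows that this position responds strongly to a single added hydroxy. The compounds shown offer no measurement that explains the loss, so the step stands as an observation only.

On these data alone, it remains open whether the loss is specific to hydroxy or would also follow from another group at this carbon, such as methoxy or an amine. One pair also leaves open whether a step of this size would recur on a different core.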